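Carbamate step from compound 3 to compound 4

The source may report more compounds than this note shows. Statements on the series, on what has been measured and on what is new or still open speak of the compounds shown alone.

Three compounds sharing one core have been entered so far, and only one of them gives a number. In a functional assay on HepG2 cells (Homo sapiens) for inhibition, read by scintillation counting, with a stated time of 2 h (a lower number here means a stronger inhibitor, a higher number a weaker inhibitor), compound 2 (`CCNC(=O)Nc1sc2ccccc2c1C(=O)N1CCN(C2CCN(C(=O)C3CCCCC3)CC2)CC1`) gives 146 nM. Under the same read-out, compound 1 (`CCNC(=O)Nc1sc2ccccc2c1C(=O)N1CCN(C2CCN(C(=O)CC(C)C)CC2)CC1`) gives "not determined" (no result reported). Compound 3 (`CCNC(=O)Nc1sc2ccccc2c1C(=O)N1CCN(C2CCN(C(=O)OC)CC2)CC1`) also has no single number, with "not determined" (no result reported) as its entry, so it shares its status with compound 1 and cannot be placed relative to compound 2.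

The next compound to be tested is compound 4 (`CCNC(=O)Nc1sc2ccccc2c1C(=O)N1CCN(C2CCN(C(=O)OC(C)C)CC2)CC1`). The structural change is isopropyl in place of methyl on an oxygen next to a carbonyl group. Among the measured compounds shown here, no step between measured compounds is available, so the size of this change cannot be read from the data.

A small step towards a lower number in this assay is expected, not far beyond the usual scatter, although this remains a tentative expectation without a value for compound 3. For the measured compounds named here, the only numerical anchor is compound 2 at 146 nM, and a wide range is therefore appropriate. The estimated value for compound 4 is 110 nM, with an expected range from 30 nM to 400 nM.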

Compound 4, half-maximal inhibitory concentration: 208 nM
Compound 4: middle estimate off by 1.9-fold (0.28 log units), on the low side; low and high end bracket the measured number.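

In this assay isopropoxy in place of cyclohexyl on a carbonyl carbon comes with a 1.4-fold higher number from compound 2 to compound 4 (0.15 log units; within the scatter) so this first readable comparison at the position does not separate the two groups. A group attached through oxygen, isopropoxy, and a ring attached directly to the carbonyl carbon, cyclohexyl, therefore cannot be told apart on this read-out, and the position now has two measured members rather than one. No accompanying measurement offers an explanation for this outcome.

Steps involving compound 1 or compound 3 cannot be read, including methyl to isopropyl on the oxygen next to the carbonyl group, so the contribution of that change remains unknown. Also open, as far as these compounds go, is whether a longer chain on that oxygen, such as n-butyl, or an amine on the carbonyl carbon in place of isopropoxy would give a number that stands clearly apart from compound 4 and compound 2.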